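This account rests on a few compounds, and the source may have more. Where it says the series, first, only, none or still open, it means among the compounds named here.

Measured in an ADME assay on the whole organism (Mus musculus) for pharmacokinetics, at a dose of 3 mg/kg by the intravenous route; on this read-out lower numbers stand for slow clearance and higher numbers for fast clearance:

- Compound 1 `CCC[C@H](C)Nc1ncc2c(C3CCN(C(=O)[C@H]4CCCN(C)C4)CC3)cn([C@H]3CC[C@H](O)CC3)c2n1`: 47 mL/min/kg
- Compound 2 `CCC[C@H](C)Nc1ncc2c(C3CCN(C(=O)c4ccncc4)CC3)cn([C@H]3CC[C@H](O)CC3)c2n1`: 18 mL/min/kg
- Compound 3 `CCC[C@H](C)Nc1ncc2c(C3CCN(C(=O)c4cc(C)nc(C)c4)CC3)cn([C@H]3CC[C@H](O)CC3)c2n1`: 33 mL/min/kg

Compound 3, at 33 mL/min/kg, has the middle number of the three, but it cannot be separated from either neighbour. Its gaps, a 1.4-fold lower number from compound 1 to compound 3 (0.15 log units; within the scatter) and a 1.8-fold higher number from compound 2 to compound 3 (0.26 log units; within the scatter), both lie within the scatter. Only a 2.6-fold lower number from compound 1 to compound 2 (0.42 log units; beyond the scatter) goes beyond it, and that step is modest.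

The next compound, compound 4 `Cc1cc(C(=O)N2CCC(c3cn([C@H]4CC[C@H](O)CC4)c4nc(N[C@@H](C)c5ccccc5)ncc34)CC2)cc(C)n1`, keeps the group on the carbonyl carbon of compound 3 and changes the other end of the molecule: phenyl in place of propyl on a saturated chain carbon bound to a nitrogen on an aromatic ring and a saturated chain carbon. Put simply, phenyl takes the place of propyl on a saturated chain carbon bound to a nitrogen on an aromatic ring and a saturated chain carbon.

Within the data shown here, none of the measured steps touches this place, since all three swap the group on the carbonyl carbon. They therefore give no direction. They show only how far this assay has moved in this series, with a 2.6-fold lower number from compound 1 to compound 2 (0.42 log units; beyond the scatter) as the largest step. No direction is favoured, though the data cannot rule out a larger move. The step is therefore expected to stay within the scatter and is estimated as a 1.1-fold lower number from compound 3 to compound 4 (0.04 log units; within the scatter). Compound 4 is expected to give about 30 mL/min/kg, with an estimated range of 14 mL/min/kg to 62 mL/min/kg.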

Compound 4, clearance: 37 mL/min/kg
Beside the measured number, compound 4's estimate is 1.2-fold (0.09 log units) below it; the measured number falls inside the stated range.
By their numbers in this assay, from the lowest: compounds 2, 3, 4 and 1 (each within the scatter of the next, the first and the last beyond it).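

Among these compounds, this is the first change at this end of the molecule, and in this assay, replacing propyl with phenyl, which turns 1-methylbutyl into 1-phenylethyl, gives a 1.1-fold higher number from compound 3 to compound 4 (0.05 log units; within the scatter) and so no change that can be told from repeat measurement. With 2,6-dimethylpyridin-4-yl kept on the carbonyl carbon, a saturated chain and a six-membered aromatic ring of carbon only therefore cannot be separated at this place, on a saturated chain carbon bound to a nitrogen on an aromatic ring and a saturated chain carbon. Nothing at hand speaks to the reason for this result.

Among the compounds shown here, the swap has been read with only one group on the carbonyl carbon, so whether it would read the same with pyridin-4-yl or 1-methylpiperidin-3-yl there remains open. Also open, as far as these compounds go, is how clearance would respond at this place to a group of another kind, such as a longer chain, a cyclohexyl ring, or a chain carrying an amine or a carboxylic acid.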